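A few compounds are considered here, and "the series" means these few. Any claim that something is new, unique, unknown or untested is made for them only; others in the source may bear on it.

Measured so far, in an assay on CHO cells for displacement of a labelled ligand from 5-hydroxytryptamine receptor 1B (Homo sapiens); on this read-out lower numbers stand for stronger inhibition and higher numbers for weaker inhibition:
- compound 1 `O[C@H]1Cc2ccccc2C1NC1CCN(CCCc2c[nH]c3ccc(-n4cnnc4)cc23)CC1`: 300 nM
- compound 2 `O[C@@H]1Cc2ccccc2[C@H]1NC1CCN(CCCc2c[nH]c3ccc(-n4cnnc4)cc23)CC1`: 210 nM
- compound 3 `CN(Cc1ccsc1)C1CCN(CCCc2c[nH]c3ccc(-n4cnnc4)cc23)CC1`: 35 nM

Compound 3 has the lowest number of the three, as the steps of an 8.6-fold lower number from compound 1 to compound 3 (0.93 log units; beyond the scatter) and a 6.0-fold lower number from compound 2 to compound 3 (0.78 log units; beyond the scatter) show; the gap between compounds 1 and 2 is a 1.4-fold lower number from compound 1 to compound 2 (0.15 log units; within the scatter) and so carries no weight. Compound 4 `C[C@H](NCC1CCN(CCCc2c[nH]c3ccc(-n4cnnc4)cc23)CC1)c1ccccc1` is not yet measured. It differs from compound 3 in that (((1-phenylethyl)amino)methyl in place of methyl((thiophen-3-yl)methyl)amino on a saturated ring carbon). For the measured compounds named here, the only measured steps at this saturated ring carbon are the two just named: both were modest and both ran toward compound 3. The entering group again pairs an amine with an aromatic ring, so only a small step is expected in this assay, perhaps toward a slightly higher number, giving an expected 1.7-fold higher number from compound 3 to compound 4 (0.23 log units; within the scatter). Compound 4 is estimated at 60 nM, expected between 15 nM and 250 nM.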

Compound 4, half-maximal inhibitory concentration: 58 nM
Compound 4: middle estimate off by 1.0-fold (0.01 log units), on the high side; measured number inside the range.
By their numbers in this assay, from the lowest: compounds 3 and 4 (each within the scatter of the next); then compounds 2 and 1 (each within the scatter of the next).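

In this assay, placing ((1-phenylethyl)amino)methyl on the saturated ring carbon instead of methyl((thiophen-3-yl)methyl)amino gives a 1.7-fold higher number from compound 3 to compound 4 (0.22 log units; within the scatter), so a group with a six-membered aromatic ring of carbon only and a hydrogen-bond donor does as well as the thiophene group. Against the (2-hydroxy-2,3-dihydro-1H-inden-1-yl)amino group, the same group gives a 3.6-fold lower number from compound 2 to compound 4 (0.56 log units; beyond the scatter) and a 5.2-fold lower number from compound 1 to compound 4 (0.71 log units; beyond the scatter), so the low numbers are not tied to thiophene.

Still open, going by these compounds, is whether a pyridine ring in place of the phenyl ring would keep this number. Nothing shown here explains any of these steps.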